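The source may hold more compounds than are shown below. What is called first, only, known or untested is meant among the compounds shown, and "the series" means these compounds.

Measured compounds:
compound 1 `COc1cc(-c2nn(-c3cccc(NC(=O)Nc4ccc(Cl)c(Cl)c4)c3)cc2-c2ccncc2)ccc1Cl`, which in a functional assay on MDA-MB-468 cells (Homo sapiens) for inhibition, read by sulforhodamine B assay, with a stated time of 48 h (on this read-out higher numbers stand for weaker inhibition of growth and lower numbers for stronger inhibition of growth), gives 2270 nM
compound 2 `O=C(Nc1cccc(-n2cc(-c3ccncc3)c(-c3ccc(Cl)c(O)c3)n2)c1)Nc1ccc(Cl)c(Cl)c1`, which in this assay gives 4250 nM

Compound 1 holds the lowest of the two numbers shown, but its only neighbour sits within the scatter: the step of a 1.9-fold higher number from compound 1 to compound 2 (0.27 log units; within the scatter), brought about by hydrogen in place of methyl on an oxygen on an aromatic ring, does not separate the two compounds.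

Compound 3 `COc1cc(-c2nn(-c3cccc(NC(=O)c4ccc(Cl)c(C(F)(F)F)c4)c3)cc2-c2ccncc2)ccc1Cl` has not yet been measured in this assay. It departs from compound 1 at a different place than compound 2 does: 4-chloro-3-(trifluoromethyl)phenyl in place of (3,4-dichlorophenyl)amino on a carbonyl carbon. Going by the values given here, the one measured step touches only the methoxy group on the shared core of compound 1 and says nothing about the carbonyl end of the molecule, where the urea of compound 1 becomes an amide in compound 3. Among the compounds with values here, no measured step therefore bears on this change, and the expectation can only be anchored on compound 1 itself.

With no guidance either way, compound 3 is expected to stay close to compound 1, so the expected step is a 1.1-fold higher number from compound 1 to compound 3 (0.04 log units; within the scatter). The estimate for compound 3 in this assay is 2500 nM, within a wide range from 700 nM to 9000 nM.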

Compound 3, concentration for total growth inhibition: > 32500 nM
Compound 3: only a limit was reported; the forecaster's own chance of this, stated with the estimate: 10%; at least 13-fold (1.11 log units) between middle value and limit.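

The carbonyl end of the molecule, which the earlier step left untouched, turns out to matter in this assay: 4-chloro-3-(trifluoromethyl)phenyl in place of (3,4-dichlorophenyl)amino on a carbonyl carbon gives an at least 14-fold higher number from compound 1 to compound 3 (1.15 log units; beyond the scatter), whereas the change on the oxygen gave only a 1.9-fold higher number from compound 1 to compound 2 (0.27 log units; within the scatter). Compound 3 has no number of its own here, only a limit of the assay: the limit of > 32500 nM in this assay, at which 1 of the 3 values shown sits. This single step turns the urea of compound 1 into an amide, removing the hydrogen-bond donor counted on the leaving group, and it also replaces a chlorine with a trifluoromethyl group on the aromatic ring, so it joins two changes and cannot say which of them accounts for the weaker growth inhibition.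

A urea carrying the 4-chloro-3-(trifluoromethyl)phenyl group, or an amide carrying the 3,4-dichlorophenyl group, would pull those two changes apart. Going by these compounds, still open as well are how far the true value of compound 3 lies past its limit and how a non-aromatic group on the carbonyl carbon, such as a cyclohexylamino or morpholine group, would read in this assay.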